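Chloro for Methoxy in a Thiazole-Pyrimidinone Pair

The source may report more compounds than this note shows. Statements on the series, on what has been measured and on what is new or still open speak of the compounds shown alone.

Compound 1, `COc1ccc(-c2nc(C)c(C(=O)CSc3nc(-c4ccc(Cl)cc4)c(C#N)c(=O)[nH]3)s2)cc1`: 48%
Compound 2, `COc1ccc(-c2nc(SCC(=O)c3sc(-c4ccc(Cl)cc4)nc3C)[nH]c(=O)c2C#N)cc1`: 46.3%

Of the compounds shown here, two have been measured in a functional assay on U-87MG ATCC cells for antiproliferative activity against U-87 MG (Homo sapiens), read by MTT assay, with a stated time of 48 h, tested at 50 uM; on this read-out higher numbers stand for a weaker effect at the one concentration tested and lower numbers for a stronger effect. Compound 1 gives 48% and compound 2 gives 46.3%; the two numbers lie within the usual scatter of one another, so nothing separates them on this read-out, and compound 2 cannot be called either the stronger or the weaker of the pair.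

Compound 3, `Cc1nc(-c2ccc(Cl)cc2)sc1C(=O)CSc1nc(-c2ccc(Cl)cc2)c(C#N)c(=O)[nH]1`, has not yet been measured. It differs from compound 2 in one place: chloro in place of methoxy on an aromatic carbon. Among the measured compounds shown here, no measured pair shows what this change does on its own, so there is no step from which to read its size. With only the two measured numbers to go by, the step from compound 2 to compound 3 is expected to be a number 0.3 percentage points lower from compound 2 to compound 3 (within the scatter), that is, none beyond the scatter. On that basis compound 3 is estimated at 46%, with a range from 26% to 66%.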

Compound 3, a percentage reported as activity, at one concentration (the size of the read-out at that concentration, not a potency): 60%
The estimate for compound 3 lay 14 percentage points below the measured number, within the range that was stated.
By their numbers in this assay, from the lowest: compounds 2 and 1 (each within the scatter of the next); then compound 3.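

In this assay, chloro in place of methoxy on an aromatic carbon now has a measured size: the change gives a number 13.7 percentage points higher from compound 2 to compound 3 (beyond the scatter) and also a number 12 percentage points higher from compound 1 to compound 3 (beyond the scatter), each towards a weaker effect at the one concentration tested. The two steps make this change in two different places of the shared structure, and they point the same way, so compound 3, with 4-chlorophenyl in both places, stands apart from the two compounds that each carry one 4-methoxyphenyl. No measurement on these compounds accounts for the steps.

The compounds shown leave open whether a compound with 4-methoxyphenyl in both places would go further in the other direction. They also leave open what a hydroxy or an amino group would give in place of methoxy.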